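This account rests on a few compounds, and the source may have more. Where it says the series, first, only, none or still open, it means among the compounds named here.

Values in a functional assay on MCF7 cells (Homo sapiens) for inhibition, read by MTT assay, with a stated time of 3 days; on this read-out lower numbers stand for stronger inhibition and higher numbers for weaker inhibition:

- Compound 1 `COc1cc(-c2nc3ccccc3s2)ccc1OCC(=O)NNC(=O)CCl`: 780 nM
- Compound 2 `COc1cc(-c2nc3ccccc3s2)ccc1OCC(=O)NNC(O)CN(C)CC(=O)O`: 1960 nM
- Compound 3 `COc1cc(-c2nc3ccccc3s2)ccc1OCC(=O)NNC(=O)CN1CCC[C@H]1C(=O)O`: 840 nM

Compound 3, at 840 nM, cannot be told apart from compound 1, and its number is lower than that of compound 2. Compound 4 `CCOC(=O)[C@H](CS)N(CC(=O)NNC(=O)COc1ccc(-c2nc3ccccc3s2)cc1OC)C(C)=O` has not yet been measured in this assay. It carries acetyl(1-(ethoxycarbonyl)-2-sulfanylethyl)amino in place of 2-carboxypyrrolidin-1-yl on a saturated chain carbon bound to a carbonyl carbon.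

The closest evidence is a 1.1-fold higher number from compound 1 to compound 3 (0.03 log units; within the scatter), where 2-carboxypyrrolidin-1-yl replaced chloro on that same kind of carbon. The two steps involving compound 2 are larger but still modest: a 2.5-fold higher number from compound 1 to compound 2 (0.40 log units; beyond the scatter) and a 2.3-fold lower number from compound 2 to compound 3 (0.37 log units; beyond the scatter). Both also alter the carbonyl, which compound 4 keeps. Within the data shown here, none of the measured compounds carries the entering group, so these three values offer only a rough guide and the range must stay wide. With such small measured steps, no step beyond the scatter is expected, and no direction can be favoured. The expected change is a 1.1-fold higher number from compound 3 to compound 4 (0.03 log units; within the scatter). For compound 4 the estimated value is 900 nM, with an expected range from 350 nM to 2300 nM.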

Compound 4, half-maximal inhibitory concentration: 1890 nM
Estimate against measurement, compound 4: 2.1-fold (0.32 log units) below, within the range that was stated.
By their numbers in this assay, from the lowest: compounds 1 and 3 (each within the scatter of the next); then compounds 4 and 2 (each within the scatter of the next).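

In this assay, the place on a saturated chain carbon bound to a carbonyl carbon turns out not to accept every group equally: acetyl(1-(ethoxycarbonyl)-2-sulfanylethyl)amino in place of 2-carboxypyrrolidin-1-yl gives a 2.3-fold higher number from compound 3 to compound 4 (0.35 log units; beyond the scatter). The earlier swap of chloro for 2-carboxypyrrolidin-1-yl stayed within the scatter, whereas the new group, measured against chloro, gives a 2.4-fold higher number from compound 1 to compound 4 (0.38 log units; beyond the scatter), so both comparisons now show a modest loss of inhibition, and the size of the step is similar from either starting point. The change removes a ring and brings in a sulfanyl, an acetyl and an ethoxycarbonyl together, and no independent measurement here accounts for the rise.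

Which of these parts carries the step stays open, and a version holding a free carboxylic acid in place of the ethoxycarbonyl, or lacking the acetyl or the sulfanyl, would begin to separate them. Also open, as far as these compounds go, is how a plain ring amine such as morpholine, or a simple longer alkyl chain, would behave on this same carbon.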